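Amide-variant cytotoxicity on HEK cells, compound 4 projection

This account rests on a few compounds, and the source may have more. Where it says the series, first, only, none or still open, it means among the compounds named here.

Measured compounds:
compound 1 `COc1ccc(-c2cn3cc(C4=CCN(S(=O)(=O)CCc5ccccc5)CC4)ccc3n2)cc1OC`, 70300 nM
compound 2 `COc1ccc(-c2cn3cc(C4=CCN(C(=O)C5CCCCC5)CC4)ccc3n2)cc1OC`, 72100 nM
compound 3 `COc1ccc(-c2cn3cc(C4=CCN(C(=O)C5CC5)CC4)ccc3n2)cc1OC`, 77600 nM

In an ADME assay on HEK293 cells (Homo sapiens) for cytotoxicity, read by MTT assay, with a stated time of 48 h (a higher number here means a weaker inhibitor, a lower number a stronger inhibitor), compound 3 gives 77600 nM, the highest of the three numbers, yet every gap to its neighbours lies within the scatter: a 1.1-fold higher number from compound 2 to compound 3 (0.03 log units; within the scatter) and a 1.1-fold higher number from compound 1 to compound 3 (0.04 log units; within the scatter), so no order among compounds 1 to 3 can be read. Compound 4 `COc1ccc(-c2cn3cc(C4=CCN(C(=O)c5cccc(C(F)(F)F)c5)CC4)ccc3n2)cc1OC` differs from compound 3 by 3-(trifluoromethyl)phenyl in place of cyclopropyl on a carbonyl carbon. Among the measured compounds shown here, no measured step makes exactly this change; the nearest are the swaps on the same nitrogen, a 1.0-fold higher number from compound 1 to compound 2 (0.01 log units; within the scatter) and a 1.1-fold higher number from compound 2 to compound 3 (0.03 log units; within the scatter), both flat. The series has shown no response to changes at this position, so the expected step is a 1.3-fold lower number from compound 3 to compound 4 (0.10 log units; within the scatter), none beyond the scatter. Compound 4 is therefore estimated at 62000 nM, with a range from 25000 nM to 130000 nM.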

Compound 4, half-maximal inhibitory concentration: 68400 nM
For compound 4 the middle estimate is 1.1-fold (0.04 log units) below the measured one; the measured number falls inside the stated range.
By their numbers in this assay, from the lowest: compounds 4, 1, 2 and 3 (each within the scatter of the next).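

In this assay the 3-(trifluoromethyl)phenyl amide stays level with all three earlier compounds, with steps of (a 1.1-fold lower number from compound 3 to compound 4 (0.05 log units; within the scatter)), (a 1.1-fold lower number from compound 2 to compound 4 (0.02 log units; within the scatter)) and (a 1.0-fold lower number from compound 1 to compound 4 (0.01 log units; within the scatter)). The flat reading at this carbonyl carbon, until now seen only for cyclohexyl and cyclopropyl, therefore extends to a six-membered aromatic ring carrying fluorine. No supporting measurement speaks to the reason for this flatness.

On these data alone, whether an amine or a carboxylic acid on this carbonyl carbon would leave the number equally flat stays open, as does any response to changes on the shared core.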